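Fluoro for Methyl on a Bromoacrylamide Series

This account rests on a few compounds, and the source may have more. Where it says the series, first, only, none or still open, it means among the compounds named here.

Compound 2 `C=C(Br)C(=O)Nc1cccc(-c2cn3nc(-c4ccc(C)cc4)sc3n2)c1`: 920 nM
Compound 3 `C=C(Br)C(=O)Nc1cccc(-c2cn3c(-c4ccccc4)csc3n2)c1`: 1300 nM
Compound 1 `COc1cccc(-c2nn3cc(-c4cccc(N)c4)nc3s2)c1`: > 250000 nM, a limit of the assay, not a number.

These values come from a functional assay on L1210 cells (Mus musculus) for inhibition, read by cell counting, with a stated time of 2 days; on this read-out higher numbers stand for weaker inhibition and lower numbers for stronger inhibition. Compound 2 gives the lowest of the two numbers, but compound 3 sits within the scatter of it, so neither can be called the stronger. For compound 1 the reading stops at the limit of > 250000 nM in this assay, at which 1 of the 3 values shown sits. Compound 4 `C=C(Br)C(=O)Nc1cccc(-c2cn3nc(-c4ccc(F)cc4)sc3n2)c1` has not yet been measured. It differs from compound 2 in a single spot: fluoro in place of methyl on an aromatic carbon. For the measured compounds named here, no measured pair shows how such a swap acts in this assay, so the change from compound 2 to compound 4 is expected to stay within the scatter, with no preferred direction: a 1.2-fold higher number from compound 2 to compound 4 (0.08 log units; within the scatter). Compound 4 is therefore expected to give about 1100 nM, between 400 nM and 3500 nM.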

Compound 4, half-maximal inhibitory concentration: 250 nM
Estimate against measurement, compound 4: 4.4-fold (0.64 log units) above, outside the stated range (below it).
By their numbers in this assay, from the lowest: compound 4; then compounds 2 and 3 (each within the scatter of the next). At a limit, above all of these: compound 1.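

The only single-place change among these compounds, 4-methylphenyl to 4-fluorophenyl, gives a shift in this assay that can be read: a 3.7-fold lower number from compound 2 to compound 4 (0.57 log units; beyond the scatter). This position on the aromatic ring is therefore sensitive to what it carries, even when one heavy atom simply replaces another. Nothing measured here accounts for the shift.

As far as these compounds go, whether a chloro group, a methoxy group or an amine at this position would give a lower or a higher number remains open. Also open, from the compounds shown here alone, is whether fluoro would have the same effect on other compounds with a different core.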